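A few compounds are considered here, and "the series" means these few. Any claim that something is new, unique, unknown or untested is made for them only; others in the source may bear on it.

Measured compounds in a functional assay on A375P cells (Homo sapiens) for antiproliferative activity, read by MTT assay, with a stated time of 48 h; on this read-out higher numbers stand for weaker inhibition and lower numbers for stronger inhibition:
Compound 1, `COc1cc(-c2nn(-c3ccc(NC(=O)Nc4cccc(Cl)c4Cl)cc3)cc2-c2ccncc2)ccc1Cl`. In this assay compound 1 gives > 20000 nM, a limit of the assay rather than a number.
Compound 2, `COc1cc(-c2nn(-c3ccc(NC(=O)Nc4ccc(Cl)c(Cl)c4)cc3)cc2-c2ccncc2)ccc1Cl`. In this assay compound 2 gives > 20000 nM, likewise a limit.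
Compound 3, `O=C(Nc1ccc(-n2cc(-c3ccncc3)c(-c3ccc(Cl)c(O)c3)n2)cc1)Nc1cccc(Cl)c1Cl`. In this assay compound 3 gives 16800 nM.

Within the data shown here, compound 3 thus holds the only number in this assay; the two other values sit at the limit of > 20000 nM in this assay, at which 2 of the 3 values shown sit. Compound 4, `O=C(Nc1ccc(-n2cc(-c3ccncc3)c(-c3ccc(Cl)c(O)c3)n2)cc1)Nc1ccc(Cl)c(C(F)(F)F)c1`, differs from compound 3 by 4-chloro-3-(trifluoromethyl)phenyl in place of 2,3-dichlorophenyl on an amide-type nitrogen. Among the measured compounds shown here, no measured step covers this change: the step from compound 1 to compound 2, a step that the two limits leave unreadable from compound 1 to compound 2, is unreadable, and an at least 1.1-fold lower number from compound 1 to compound 3 (0.07 log units; that floor lies within the scatter) concerns the oxygen, not the amide-type nitrogen. For compound 4 the expected step is therefore of no clear direction, a 1.2-fold higher number from compound 3 to compound 4 (0.08 log units; within the scatter), with a real chance of a limit being reported. Compound 4 is estimated at 20000 nM, expected between 6000 nM and 60000 nM.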

Compound 4, half-maximal inhibitory concentration: 14900 nM
For compound 4 the middle estimate is 1.3-fold (0.13 log units) above the measured one; measured number inside the range.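

Among these compounds, on the amide-type nitrogen, 4-chloro-3-(trifluoromethyl)phenyl in place of 2,3-dichlorophenyl gives the only readable step at this position in this assay: a 1.1-fold lower number from compound 3 to compound 4 (0.05 log units; within the scatter). With hydrogen on the oxygen, these two aryl groups are therefore not told apart on this read-out. The earlier step at this nitrogen, between compound 1 and compound 2, cannot be read, as both of their values are limits of the assay rather than numbers: the limit of > 20000 nM in this assay, at which 2 of the 4 values shown sit.

On these data alone, whether a phenyl carrying a carboxylic acid or an amine on this nitrogen would shift the number beyond the scatter remains open. Also open, as far as these compounds go, is whether the same exchange reads alike with methyl on the oxygen.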